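Same Aryl Swap, Seen Once, Expected Again

This account rests on a few compounds, and the source may have more. Where it says the series, first, only, none or still open, it means among the compounds named here.

All values below come from a functional assay on MKN-45 cells (Homo sapiens) for inhibition, read by CCK-8 assay, with a stated time of 24 h; a higher number here means a weaker inhibitor, a lower number a stronger inhibitor.

Compound 1 `Cc1ccccc1-n1cc(-c2ccc(/C=C3\C(=O)Nc4ccccc43)cc2)nn1`: 9770 nM
Compound 2 `O=C1Nc2ccccc2/C1=C/c1ccc(-c2cn(-c3ccc(Cl)cc3)nn2)cc1`: 16200 nM
Compound 3 `Cc1ccccc1-n1cc(-c2ccc(C=C3C(=O)Nc4ccc(F)cc43)cc2)nn1`: 7210 nM

Compound 1 and compound 2 differ in one place only, (4-chlorophenyl in place of 2-methylphenyl on an aromatic nitrogen). In this assay that change gave a 1.7-fold higher number from compound 1 to compound 2 (0.22 log units; within the scatter), a step that stays within the usual scatter of repeated measurements, so the two values cannot be put in order with confidence. Compound 3 carries a different core from compound 1; the difference between the two cores is not broken down here. Among the measured compounds shown here, its value is the lowest of the three so far, with compound 1 nearest and compound 2 furthest from it, the gap to compound 2 lying beyond the scatter.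

Compound 4 `O=C1Nc2ccc(F)cc2C1=Cc1ccc(-c2cn(-c3ccc(Cl)cc3)nn2)cc1` has not yet been measured. It stands to compound 3 as compound 2 stands to compound 1: the change is 4-chlorophenyl in place of 2-methylphenyl on an aromatic nitrogen, and the place around it reads the same as in the earlier pair, so this is the same change on a different core. For the measured compounds named here, the only guide is the single earlier step, which was small. The step from compound 3 to compound 4 is therefore expected to be about a 1.7-fold higher number from compound 3 to compound 4 (0.22 log units; within the scatter). Going by the values given here, that expectation rests on compound 1 at 9770 nM and on compound 2 at 16200 nM and on nothing else, since that pair is the only instance available. Compound 4 is accordingly estimated at 12000 nM in this assay, with a plausible range from 6000 nM to 25000 nM.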

Compound 4, half-maximal inhibitory concentration: 15800 nM
The estimate for compound 4 lay 1.3-fold (0.12 log units) below the measured number; measured number inside the range.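

In this assay, placing 4-chlorophenyl where 2-methylphenyl stood on the aromatic nitrogen of the second core gave a 2.2-fold higher number from compound 3 to compound 4 (0.34 log units; beyond the scatter), a modest step. Set beside the earlier step on the first core, it shows that the swap carried across these two cores without a difference that can be told apart, even though only the newer of the two steps lies beyond the scatter when taken alone: the same change on two cores in this assay, a 1.7-fold higher number (0.22 log units; within the scatter) from compound 1 to compound 2 and a 2.2-fold higher number (0.34 log units; beyond the scatter) from compound 3 to compound 4, 1.3-fold (0.12 log units) apart, within the scatter of two such steps This is agreement between just two pairs of compounds, so it does not show that the step would keep its size on any further core, and it says nothing about why the swap acts as it does or whether the earlier step, read alone, is a real change at all.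

The compounds shown leave open how other groups on the aromatic nitrogen would fare in this assay, such as a phenyl ring carrying an amine or a carboxylic acid, or a longer alkyl chain in place of the aryl ring. They also leave open whether a chlorine or a methoxy group in place of the fluorine of compound 3 would behave as that core does when the same swap is made.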